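The source may hold more compounds than are shown below. What is called first, only, known or untested is meant among the compounds shown, and "the series" means these compounds.

Of the compounds shown here, three built on one shared core have been measured in an in vivo ADME assay on the whole organism (plasma) for pharmacokinetics, with Rattus norvegicus as the target, at a dose of 50 mg/kg by the oral route; a lower number here means less compound in the circulation, a higher number more compound in the circulation at the dose given. Compound 2 `Cc1cc(C)c(NC(=O)c2sccc2S(=O)(=O)Nc2onc(C)c2Cl)c(C)c1O` gives 106000 nM there. Compound 1 `COc1c(C)cc(C)c(NC(=O)c2sccc2S(=O)(=O)Nc2onc(C)c2Cl)c1C` gives 8510 nM in this assay. Within the data shown here, the single change between them is methyl in place of hydrogen on an oxygen on an aromatic ring, and it made the step of a 12-fold lower number from compound 2 to compound 1 (1.10 log units; beyond the scatter). Among the measured compounds shown here, compound 3 `C/C(=N\O)c1cc(C)cc(C)c1NC(=O)c1sccc1S(=O)(=O)Nc1onc(C)c1Cl` gives 14300 nM in this assay; that number and the one for compound 1 lie within the scatter of each other, whereas the gap to compound 2 is beyond it. How the core of compound 3 differs from the core of compound 2 is not broken down here.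

Compound 4 `CO/N=C(\C)c1cc(C)cc(C)c1NC(=O)c1sccc1S(=O)(=O)Nc1onc(C)c1Cl` is not yet measured. It differs from compound 3 by methyl in place of hydrogen on an oxygen. For the measured compounds named here, this is the same kind of change as the one from compound 2 to compound 1, not the same: in compound 2 the oxygen sits on an aromatic ring with an aromatic carbon as its other neighbour, while in compound 3 the oxygen's other neighbour is a double-bonded nitrogen. Because the earlier step was a 12-fold lower number from compound 2 to compound 1 (1.10 log units; beyond the scatter), a drop is expected. Given the different surroundings, a smaller step is expected, estimated at a 2.4-fold lower number from compound 3 to compound 4 (0.38 log units; beyond the scatter). Compound 4 is therefore estimated at 6000 nM, between 1500 nM and 25000 nM.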

Compound 4, maximal plasma concentration: 27800 nM
Compound 4: middle estimate off by 4.6-fold (0.67 log units), on the low side, and the stated range ends below it.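

In this assay, methyl in place of hydrogen on an oxygen whose other neighbour is a double-bonded nitrogen gave a 1.9-fold higher number from compound 3 to compound 4 (0.29 log units; within the scatter), a step that cannot be told apart from no change. The large drop seen when the same change was made on the aromatic oxygen therefore did not carry over to this core, and the two steps truly differ: the same change on two cores in this assay, a 12-fold lower number (1.10 log units; beyond the scatter) from compound 2 to compound 1 and a 1.9-fold higher number (0.29 log units; within the scatter) from compound 3 to compound 4, 24-fold (1.38 log units) apart, beyond the scatter of two such steps This shows that, across these two pairs, the size of the step cannot be taken from one core to the other, but it does not show which difference between the cores or the oxygen's surroundings is responsible, and two pairs set no rule for the series.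

The compounds shown leave open how a longer chain, such as ethyl, or a chain ending in a carboxylic acid would behave on the same oxygen of either core. They also leave open whether the contrast between the two pairs would hold at another dose or by another route.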